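Swapping cyano for formyl on a shared core

The compounds below may be only part of what the source reports. "The series", "measured", "known", "first", "only" and "open" are said of these compounds alone.

In a toxicity assay on CCRF-CEM cells (Homo sapiens) for cytotoxicity (a higher number here means that more compound is tolerated, a lower number that less compound is tolerated), compound 1 (`COc1cccc2c1nc(-c1c(F)cccc1F)n2Cc1c(F)cccc1F`) gives 44.3 uM, and compound 3 (`N#Cc1cccc2c1nc(-c1c(F)cccc1F)n2Cc1c(F)cccc1F`) gives 26.7 uM. Compound 2 (`Oc1cccc2c1nc(-c1c(F)cccc1F)n2Cc1c(F)cccc1F`) reads > 100 uM, which is a limit of the assay and not a number. Among the compounds with values here, compound 3 therefore stands level with compound 1, the only other compound with a true number, as the measured step is a 1.7-fold lower number from compound 1 to compound 3 (0.22 log units; within the scatter).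

Compound 4 (`O=Cc1cccc2c1nc(-c1c(F)cccc1F)n2Cc1c(F)cccc1F`) differs from compound 3 in one place: formyl in place of cyano on an aromatic carbon. Within the data shown here, no measured step involves formyl, so the evidence is indirect. Among the swaps at this same place, the hydroxy compound stands apart, with an at least 2.2-fold higher number from compound 1 to compound 2 (0.35 log units; beyond the scatter) and an at least 3.7-fold lower number from compound 2 to compound 3 (0.57 log units; beyond the scatter). The swap between methoxy and cyano, two groups without that hydroxy, stayed small at a 1.7-fold lower number from compound 1 to compound 3 (0.22 log units; within the scatter). A change beyond the scatter in this assay is therefore not expected, and the estimated step is a 1.2-fold higher number from compound 3 to compound 4 (0.08 log units; within the scatter). Compound 4 is expected to give about 32 uM, with an estimated range of 14 uM to 75 uM.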

Compound 4, half-maximal toxic concentration: 0.82 uM
Beside the measured number, compound 4's estimate is 39-fold (1.59 log units) above it; the measured number lies below the stated range.
By their numbers in this assay, from the lowest: compound 4; then compounds 3 and 1 (each within the scatter of the next). At a limit, above all of these: compound 2.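

In this assay, within the data shown here, this position on the shared core turns out to be far more sensitive than the earlier compounds suggested: swapping cyano for formyl, with no change in the counts of heavy atoms, donors or acceptors, gives a 33-fold lower number from compound 3 to compound 4 (1.51 log units; beyond the scatter). Formyl stands just as far apart from methoxy, with a 54-fold lower number from compound 1 to compound 4 (1.73 log units; beyond the scatter), although methoxy and cyano themselves lie within the scatter of each other. The gap to the hydroxy compound is wider still, at an at least 120-fold lower number from compound 2 to compound 4 (2.08 log units; beyond the scatter), and the reading of compound 2 is a limit of the assay: the limit of > 100 uM in this assay, at which 1 of the 4 values shown sits.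

The compounds shown leave open whether this drop belongs to formyl alone or also appears with other carbonyl groups at this place, such as an acetyl, a carboxylic acid or an amide. What lies behind the drop also stays open, for nothing shown speaks to a cause.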